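The source may hold more compounds than are shown below. What is called first, only, known or untested is meant among the compounds shown, and "the series" means these compounds.

In a functional assay on MCF7 cells (Homo sapiens) for cytotoxicity, read by MTT assay, with a stated time of 48 h (on this read-out higher numbers stand for weaker inhibition and lower numbers for stronger inhibition), three compounds sharing one core have been measured: compound 1 `COc1ccc(/C=C2/S/C(=N/c3ccccc3)N(Cc3ccncc3)C2=O)cc1` gives 31500 nM, compound 2 `O=C1/C(=C\c2ccc([N+](=O)[O-])cc2)S/C(=N/c2ccccc2)N1Cc1ccncc1` gives 13000 nM, and compound 3 `CN(C)c1ccc(/C=C2/S/C(=N/c3ccccc3)N(Cc3ccncc3)C2=O)cc1` gives 76300 nM, the highest number and so the weakest inhibition of the three. Compound 4 `COc1cc(/C=C2/S/C(=N/c3ccccc3)N(Cc3ccncc3)C2=O)ccc1O` is not yet measured and differs from compound 3 by one change: 4-hydroxy-3-methoxyphenyl in place of 4-(dimethylamino)phenyl on a double-bonded chain carbon bound to a double-bonded ring carbon. The closest evidence is a 2.4-fold higher number from compound 1 to compound 3 (0.38 log units; beyond the scatter), with dimethylamino in place of methoxy, and a 5.9-fold higher number from compound 2 to compound 3 (0.77 log units; beyond the scatter), with dimethylamino in place of nitro. Within the data shown here, compound 4 loses the dimethylamino and keeps a methoxy, as compound 1 does, but its hydroxy group has no measured precedent. In this assay, a modest drop is therefore expected, estimated as a 2.5-fold lower number from compound 3 to compound 4 (0.41 log units; beyond the scatter). For compound 4, the estimated value is 30000 nM, with an expected range of 12000 nM to 75000 nM.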

Compound 4, half-maximal inhibitory concentration: 28000 nM
Estimate against measurement, compound 4: 1.1-fold (0.03 log units) above; the measured number falls inside the stated range.
By their numbers in this assay, from the lowest: compound 2; then compounds 4 and 1 (each within the scatter of the next); then compound 3.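

With the 4-hydroxy-3-methoxyphenyl group in place of 4-methoxyphenyl, the two numbers cannot be told apart (a 1.1-fold lower number from compound 1 to compound 4 (0.05 log units; within the scatter)), so the added hydroxy group shows no effect of its own in this pair. Replacing 4-(dimethylamino)phenyl gives stronger inhibition (a 2.7-fold lower number from compound 3 to compound 4 (0.44 log units; beyond the scatter)), while 4-nitrophenyl still gives the strongest inhibition of the four (a 2.2-fold higher number from compound 2 to compound 4 (0.33 log units; beyond the scatter)). On these data alone, whether a carboxylic acid or a simple amine on the aromatic ring would lower the number further remains open. No measurement shown accounts for these differences.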